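Sulfonyl hydrazide series: methylsulfonyl to cyano step

This account rests on a few compounds, and the source may have more. Where it says the series, first, only, none or still open, it means among the compounds named here.

Compound 1 `Cc1cccc(NNS(=O)(=O)c2ccc(C(=O)NCC(=O)O)cc2)c1`: 80 nM in an assay for inhibition of Indoleamine 2,3-dioxygenase 1 (Homo sapiens), read by spectrophotometry, with stated times of 1 h and 4 h; on this read-out lower numbers stand for stronger inhibition and higher numbers for weaker inhibition
Compound 2 `Cc1cccc(NNS(=O)(=O)c2ccc(S(C)(=O)=O)cc2)c1`: 43 nM in this assay

Compound 2 has the lowest of the two numbers in this assay; its nearest neighbour is compound 1, and the step of a 1.9-fold lower number from compound 1 to compound 2 (0.27 log units; within the scatter) lies within the scatter, so no order between the two is claimed. Compound 3 `Cc1cccc(NNS(=O)(=O)c2ccc(C#N)cc2)c1` is not yet measured. It differs from compound 2 by cyano in place of methylsulfonyl on an aromatic carbon. Within the data shown here, the only measured step, a 1.9-fold lower number from compound 1 to compound 2 (0.27 log units; within the scatter), swaps one group at the same place and stays within the scatter; it is the sole guide available. Among the measured compounds shown here, no measured step shows a cyano group, so the expected step of a 1.2-fold higher number from compound 2 to compound 3 (0.07 log units; within the scatter) in this assay is none beyond the scatter. Compound 3 is therefore estimated at 50 nM, with a range from 20 nM to 130 nM.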

Compound 3, half-maximal inhibitory concentration: 59 nM
The estimate for compound 3 lay 1.2-fold (0.07 log units) below the measured number; measured number inside the range.
By their numbers in this assay, from the lowest: compounds 2, 3 and 1 (each within the scatter of the next).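

In this assay, cyano (2 heavy atoms, 1 hydrogen-bond acceptor) in place of methylsulfonyl (4 heavy atoms, 2 hydrogen-bond acceptors), on an aromatic carbon para to a large group, gives (a 1.4-fold higher number from compound 2 to compound 3 (0.14 log units; within the scatter)), and cyano in place of (carboxymethyl)carbamoyl gives (a 1.4-fold lower number from compound 1 to compound 3 (0.13 log units; within the scatter)). Both steps stay within the scatter, so this position now shows three different groups, including the smallest so far and one without sulfur, that cannot be told apart on this read-out. No available evidence bears on why these groups read alike.

The compounds shown leave open whether an amine, a methoxy group or a longer alkyl chain at this carbon would separate from these three. They also leave open whether any change at this position moves the number beyond the scatter.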